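The source may hold more compounds than are shown below. What is called first, only, known or untested is meant among the compounds shown, and "the series" means these compounds.

In a functional assay on U-937 cells (Homo sapiens) for antiproliferative activity, read by MTT assay, with a stated time of 24 h (on this read-out lower numbers stand for stronger inhibition and higher numbers for weaker inhibition), compound 1 `CCCCNC(=O)COc1ccc(C(=O)c2c(CCCC)oc3ccccc23)cc1` gives 22800 nM and compound 2 `CCCCc1oc2ccccc2c1C(=O)c1ccc(OCC(=O)N2CCCC2)cc1` gives 32500 nM, which places compound 2 level with compound 1 within the scatter. Compound 3 `CCCCc1oc2ccccc2c1C(=O)c1ccc(OCC(=O)N2CCCCC2)cc1` differs from compound 2 by piperidin-1-yl in place of pyrrolidin-1-yl on a carbonyl carbon, with piperidin-1-yl in place of pyrrolidin-1-yl on a carbonyl carbon. Among the measured compounds shown here, the one measured step bearing on this change sits on that same carbonyl carbon, a 1.4-fold higher number from compound 1 to compound 2 (0.15 log units; within the scatter), so nothing beyond the scatter is expected here. The expected step is a 1.1-fold lower number from compound 2 to compound 3 (0.03 log units; within the scatter). For compound 3 the estimated value is 30000 nM, with an expected range of 14000 nM to 60000 nM.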

Compound 3, half-maximal inhibitory concentration: 37100 nM
Beside the measured number, compound 3's estimate is 1.2-fold (0.09 log units) below it; measured number inside the range.
By their numbers in this assay, from the lowest: compounds 1, 2 and 3 (each within the scatter of the next).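

With piperidin-1-yl on the carbonyl carbon, this assay gives a 1.1-fold higher number from compound 2 to compound 3 (0.06 log units; within the scatter) and a 1.6-fold higher number from compound 1 to compound 3 (0.21 log units; within the scatter) as well, so both steps stay within the scatter. The earlier compounds shown here covered only butylamino and pyrrolidin-1-yl, whereas three different amine groups at this place now read as level with one another. Nothing measured here accounts for this flat outcome. Still open, from the compounds shown here alone, is whether a group such as morpholin-4-yl or a longer-chain amine on this carbonyl carbon would leave the number level. Going by these compounds, a carboxylic acid in place of the amide is equally open.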